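Swapping the sulfonyl's aryl for a small ring

The source may report more compounds than this note shows. Statements on the series, on what has been measured and on what is new or still open speak of the compounds shown alone.

Two compounds share one core. Compound 1 `COc1c(NS(=O)(=O)c2ccc(F)cc2)cc(-c2ccc3nc(NC4CC4)sc3c2)cc1C(N)=O` has no result: in a functional assay on A549 cells (Homo sapiens) for antiproliferative activity, read by MTT assay, with a stated time of 72 h (a lower number here means a stronger inhibitor, a higher number a weaker inhibitor), compound 1 gives "not determined" (no result reported). For the measured compounds named here, compound 2 `COc1c(NS(=O)(=O)c2ccc(F)cc2)cc(-c2ccc3nc(NC(=O)C4CC4)sc3c2)cc1C(N)=O` is the only one with a number: in this assay compound 2 gives 6340 nM, so it stands alone, with nothing to compare against. Compound 3 `COc1c(NS(=O)(=O)C2CC2)cc(-c2ccc3nc(NC(=O)C4CC4)sc3c2)cc1C(N)=O` differs from it at one place: cyclopropyl in place of 4-fluorophenyl on a sulfonyl sulfur. Going by the values given here, no measured pair shows what this change does. I expect a small step, estimated as a 1.3-fold higher number from compound 2 to compound 3 (0.10 log units; within the scatter), that may lie within the usual scatter. For compound 3 I estimate 8000 nM, expected between 2500 nM and 25000 nM.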

Compound 3, half-maximal inhibitory concentration: 46300 nM
Compound 3: middle estimate off by 5.8-fold (0.76 log units), on the low side; measured number above the stated range.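

In this assay, for the compounds shown here, putting cyclopropyl in place of 4-fluorophenyl on the sulfonyl sulfur gives a 7.3-fold higher number from compound 2 to compound 3 (0.86 log units; beyond the scatter), the first sign that the group here matters: compound 3 is the weaker inhibitor. Nothing available explains why the number rises. The compounds shown leave open whether the aromatic ring or its fluorine accounts for the difference, since only these two groups can be compared at this place. A plain phenyl, a methyl or a longer chain such as n-butyl on the same sulfur would be needed to tell.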